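This account rests on a few compounds, and the source may have more. Where it says the series, first, only, none or still open, it means among the compounds named here.

The measured compounds, each in a functional assay on A549 cells (Homo sapiens) for antiproliferative activity, read by CCK-8 assay, with a stated time of 72 h; a lower number here means a stronger inhibitor, a higher number a weaker inhibitor:
Compound 1, `Cc1ccc(C(=O)Nc2cccc(-c3oc4cc(-c5ccc(F)cc5)ccc4c(=O)c3O)c2)cc1`, gives 6910 nM.
Compound 2, `Cc1ccccc1C(=O)Nc1cccc(-c2oc3cc(-c4ccc(F)cc4)ccc3c(=O)c2O)c1`, gives 17600 nM.
Compound 3, `O=C(Nc1cccc(-c2oc3cc(-c4ccc(F)cc4)ccc3c(=O)c2O)c1)c1cccc(F)c1`, gives 15400 nM.

Among these three numbers compound 3 stands second highest. Its nearest neighbour is compound 2, and the gap between them, a 1.1-fold lower number from compound 2 to compound 3 (0.06 log units; within the scatter), is within the scatter, so the two cannot be ordered. Its furthest neighbour is compound 1, and that gap, a 2.2-fold higher number from compound 1 to compound 3 (0.35 log units; beyond the scatter), is beyond the scatter, so compound 1 is the stronger inhibitor of the pair.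

Compound 4, `O=C(Nc1cccc(-c2oc3cc(-c4ccc(F)cc4)ccc3c(=O)c2O)c1)c1ccc([N+](=O)[O-])cc1`, is not yet measured. The change from compound 3 is 4-nitrophenyl in place of 3-fluorophenyl on a carbonyl carbon. Three measured steps vary the same group on the carbonyl carbon: a 2.5-fold higher number from compound 1 to compound 2 (0.41 log units; beyond the scatter), a 2.2-fold higher number from compound 1 to compound 3 (0.35 log units; beyond the scatter) and a 1.1-fold lower number from compound 2 to compound 3 (0.06 log units; within the scatter). All are modest or within the scatter, so exchanging this group has so far moved the number only a little. For the measured compounds named here, none of them brings in a 4-nitrophenyl, so the data give no direct precedent for that group. Compound 4 is therefore expected to lie close to compound 3, with a small step of a 1.4-fold lower number from compound 3 to compound 4 (0.15 log units; within the scatter) that may not exceed the scatter. The estimate for compound 4 is 11000 nM, within a range from 4000 nM to 30000 nM.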

Compound 4, half-maximal inhibitory concentration: 2440 nM
The estimate for compound 4 lay 4.5-fold (0.65 log units) above the measured number, and the stated range ends above it.
By their numbers in this assay, from the lowest: compound 4; then compound 1; then compounds 3 and 2 (each within the scatter of the next).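

In this assay, compound 4 is the strongest inhibitor of the four, and its 4-nitrophenyl on the carbonyl carbon gives steps beyond the scatter against all three earlier compounds (a 6.3-fold lower number from compound 3 to compound 4 (0.80 log units; beyond the scatter); a 7.2-fold lower number from compound 2 to compound 4 (0.86 log units; beyond the scatter); a 2.8-fold lower number from compound 1 to compound 4 (0.45 log units; beyond the scatter)). The earlier exchanges at this place had moved the number only a little, whereas the steps from compound 2 and compound 3 are the largest seen here, so this position responds more strongly than those compounds showed. Even nitro in place of methyl on an aromatic carbon, the smallest of the three changes, lowers the number beyond the scatter, and nothing available explains this gain.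

Going by these compounds, it remains open whether an amine, a nitrile or a carboxylic acid in place of the nitro would keep the lower number. Whether a 3-nitrophenyl or 2-nitrophenyl would match the 4-nitrophenyl is also unresolved.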